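The source may hold more compounds than are shown below. What is called first, only, known or untested is meant among the compounds shown, and "the series" means these compounds.

Compound 1 `Oc1ccc(N2CCN(CC(O)COc3cccc4ccccc34)CC2)c(O)c1`: in an ADME assay on HEK293 cells (Homo sapiens) for cytotoxicity, read by MTT assay, with a stated time of 48 h (a higher number here means a weaker inhibitor, a lower number a stronger inhibitor), compound 1 gives > 50000 nM, a limit of the assay.
Compound 2 `COc1cc(O)ccc1N1CCN(CC(O)COc2ccc(O)c3ccccc23)CC1`: in this assay compound 2 gives > 50000 nM, a limit of the assay.
Compound 3 `Oc1ccccc1N1CCN(CC(O)COc2ccc(O)c3ccccc23)CC1`: in this assay compound 3 gives > 50000 nM, a limit of the assay.

Compound 3 stands where every measured member of the series stands, at the limit of > 50000 nM in this assay, at which 3 of the 3 values shown sit. No numbered value exists for it. Among the compounds with values here, the only step within the measured set, a step that the two limits leave unreadable from compound 2 to compound 3, is unreadable; both of its ends sit at the same limit.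

Compound 4 `Oc1ccc(N2CCN(CC(O)COc3ccc(O)c4ccccc34)CC2)c(O)c1` differs from compound 3 by hydroxy in place of hydrogen on an aromatic carbon. Within the data shown here, no measured step bears on this change directly; the one measured step concerns the group on the amine nitrogen in a ring and gives no readable size. With all three measured compounds at the limit, no direction can be taken from the data, and the expectation for compound 4 is that it stays there too, so the step that the limit leaves unreadable from compound 3 to compound 4 is expected to be none beyond the scatter. Compound 4 is therefore estimated at 60000 nM, range 30000 nM to 200000 nM, with a limit rather than a number the likely outcome.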

Compound 4, half-maximal inhibitory concentration: 40400 nM
Compound 4: the middle estimate sits 1.5-fold (0.17 log units) above what was measured, within the range that was stated.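

Within the data shown here, compound 4 is the only one of the four compounds with a number rather than a limit in this assay. The change from 2-hydroxyphenyl to 2,4-dihydroxyphenyl gives an at least 1.2-fold lower number from compound 3 to compound 4 (0.09 log units; that floor lies within the scatter), hydrogen in place of methyl on the oxygen gives an at least 1.2-fold lower number from compound 2 to compound 4 (0.09 log units; that floor lies within the scatter), and the hydroxy that compound 1 lacks gives an at least 1.2-fold lower number from compound 1 to compound 4 (0.09 log units; that floor lies within the scatter). Each of these floors stays within the scatter, so the new hydroxy brings a readable value but no shown shift in size, and the other compounds remain at the limit: the limit of > 50000 nM in this assay, at which 3 of the 4 values shown sit.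

From the compounds shown here alone, how far compound 1, compound 2 and compound 3 actually lie from compound 4 stays open, with only floors to go on. Also open, going by these compounds, is whether an amino group or a fluorine atom in place of the new hydroxy would give a number in this range.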